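The source may hold more compounds than are shown below. What is called first, only, known or untested is meant among the compounds shown, and "the series" means these compounds.

The measured compounds:
compound 1 `CC(=O)c1ccc(NC(=O)/C=C/C(=O)N2C/C(=C\c3ccccc3)C(=O)/C(=C/c3ccccc3)C2)cc1`, which in a functional assay on L1210 cells (Mus musculus) for cytotoxicity (a lower number here means a stronger inhibitor, a higher number a weaker inhibitor), gives 5500 nM;
compound 2 `Cc1cccc(C)c1NC(=O)/C=C/C(=O)N1C/C(=C\c2ccc([N+](=O)[O-])cc2)C(=O)/C(=C/c2ccc([N+](=O)[O-])cc2)C1`, which in this assay gives 690 nM.

Among the measured compounds shown here, of these two numbers compound 1 stands highest, and its only neighbour, compound 2, sits at a lower number with a gap beyond the scatter; the two structures differ in more than one place, so the pair shows only its two values. Compound 3 `O=C(/C=C/C(=O)N1C/C(=C\c2ccccc2)C(=O)/C(=C/c2ccccc2)C1)Nc1ccccc1` arises from compound 1 by the change (hydrogen in place of acetyl on an aromatic carbon), hydrogen in place of acetyl on an aromatic carbon. For the measured compounds named here, no measured pair differs only in this way. For compound 3 the step of a 1.1-fold higher number from compound 1 to compound 3 (0.04 log units; within the scatter) is expected to be small, not beyond the scatter. Compound 3 is therefore estimated at 6000 nM in this assay, within 2000 nM to 18000 nM.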

Compound 3, half-maximal inhibitory concentration: 3600 nM
For compound 3 the middle estimate is 1.7-fold (0.22 log units) above the measured one; the measured number falls inside the stated range.
By their numbers in this assay, from the lowest: compound 2; then compounds 3 and 1 (each within the scatter of the next).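

Among the compounds shown here, the step of a 1.5-fold lower number from compound 1 to compound 3 (0.18 log units; within the scatter) is the first comparison in this assay between compounds that differ in one place, and it lies within the scatter. On this aromatic carbon, para to a large group, hydrogen and acetyl therefore cannot be told apart, so 4-acetylphenyl and phenyl read alike here. Nothing measured on these compounds offers an explanation for this result.

On these data alone, whether an amine, a carboxylic acid or a methoxy group on this carbon would also stay within the scatter of compound 1 remains open.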